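The source may hold more compounds than are shown below. What is called first, only, known or untested is meant among the compounds shown, and "the series" means these compounds.

Compound 1, `Cc1nn(C)c(Oc2cccc(Cl)c2)c1/C=N\CCCCCCOc1cc2oc(=O)cc(C)c2cc1Cl`: in a functional assay on SMMC-7721 cells (Homo sapiens) for antiproliferative activity, read by MTT assay, with a stated time of 72 h (a lower number here means a stronger inhibitor, a higher number a weaker inhibitor), compound 1 gives 5260 nM.
Compound 2, `Cc1nn(C)c(Oc2ccc(Cl)cc2)c1/C=N\CCCCCCOc1cc2oc(=O)cc(C)c2cc1Cl`: compound 2 gives 2080 nM.
Compound 3, `Cc1nn(C)c(Oc2ccc(Br)cc2)c1/C=N\CCCCCCOc1cc2oc(=O)cc(C)c2cc1Cl`: compound 3 gives 3090 nM.

Compound 3 stands second highest of the three numbers, but its gaps to both neighbours are within the scatter: a 1.5-fold higher number from compound 2 to compound 3 (0.17 log units; within the scatter), and a 1.7-fold lower number from compound 1 to compound 3 (0.23 log units; within the scatter). The three compounds share one core and differ only in the aryl group on the ether oxygen. Compound 4, `Cc1nn(C)c(Oc2cccc(C(F)(F)F)c2)c1/C=N\CCCCCCOc1cc2oc(=O)cc(C)c2cc1Cl`, carries 3-(trifluoromethyl)phenyl in place of 4-bromophenyl on an oxygen on an aromatic ring.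

For the measured compounds named here, two measured steps bear on this change. The move from the 3-chlorophenyl of compound 1 to a 4-substituted ring gave a 2.5-fold lower number from compound 1 to compound 2 (0.40 log units; beyond the scatter), yet the parallel move to compound 3 gave a 1.7-fold lower number from compound 1 to compound 3 (0.23 log units; within the scatter). Going by the values given here, the reverse direction, back to a 3-substituted ring, is thus expected to cost at most a modest amount, and no measured step tells how a trifluoromethyl group behaves here. Compound 4 is therefore expected to show a 1.4-fold higher number from compound 3 to compound 4 (0.13 log units; within the scatter), a small rise in the number. The estimate for compound 4 in this assay is 4200 nM, with a range from 1800 nM to 9500 nM.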

Compound 4, half-maximal inhibitory concentration: 24800 nM
For compound 4 the middle estimate is 5.9-fold (0.77 log units) below the measured one; measured number outside the range, above it.
By their numbers in this assay, from the lowest: compounds 2, 3 and 1 (each within the scatter of the next, the first and the last beyond it); then compound 4.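

In this assay, for the compounds shown here, the halogen swaps among the earlier compounds moved the number only slightly, but trifluoromethyl in place of chloro on the same ring gives a clear rise (a 4.7-fold higher number from compound 1 to compound 4 (0.67 log units; beyond the scatter)), so this position is sensitive to the identity of the group and not only to where it sits. Against the two 4-halophenyl compounds the rise is larger (an 8.0-fold higher number from compound 3 to compound 4 (0.90 log units; beyond the scatter); a 12-fold higher number from compound 2 to compound 4 (1.08 log units; beyond the scatter)), which sets compound 4 apart from all three earlier compounds. No measurement given here accounts for this rise.

As far as these compounds go, what 4-(trifluoromethyl)phenyl on the same oxygen would give remains open, and with it whether the rise follows the trifluoromethyl group wherever it stands on the ring. Also open, from the compounds shown here alone, is how a methoxy group or an amine on this ring would read.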